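A Difluorophenyl Swap on Three Inactive Nucleoside Analogues

The source may hold more compounds than are shown below. What is called first, only, known or untested is meant among the compounds shown, and "the series" means these compounds.

Three compounds share one core and differ only in the group on an aromatic carbon of that core. Compound 1 `Nc1ncnn2c([C@@H]3O[C@H](CO)[C@@H](O)[C@H]3O)cc(C#Cc3cccs3)c12` carries a thiophen-2-yl on a triple-bonded carbon, compound 2 `Nc1ncnn2c([C@@H]3O[C@H](CO)[C@@H](O)[C@H]3O)cc(C#Cc3ccccc3)c12` a phenyl on a triple-bonded carbon, and compound 3 `Nc1ncnn2c([C@@H]3O[C@H](CO)[C@@H](O)[C@H]3O)cc(-c3ccccc3)c12` a phenyl joined directly. In a functional assay on HL-60 cells (Homo sapiens) for antiproliferative activity, with a stated time of 72 h (a higher number here means a weaker inhibitor, a lower number a stronger inhibitor), compound 1 gives > 100000 nM, which is a limit of the assay and not a number. In this assay compound 2 gives > 100000 nM, again a limit. In this assay compound 3 also gives > 100000 nM, a limit. The steps between them, a step that the two limits leave unreadable from compound 1 to compound 2, a step that the two limits leave unreadable from compound 1 to compound 3 and a step that the two limits leave unreadable from compound 2 to compound 3, cannot be sized because of the limit of > 100000 nM in this assay, at which 3 of the 3 values shown sit. Compound 3 thus stands at the same limit as the other two, with no number to place it higher or lower.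

Compound 4 `Nc1ncnn2c([C@@H]3O[C@H](CO)[C@@H](O)[C@H]3O)cc(-c3ccc(F)cc3F)c12` is the next step: 2,4-difluorophenyl in place of phenyl on an aromatic carbon. Among the measured compounds shown here, no measured step reads out a size, so none says in which direction this change moves activity in this assay. With every neighbour sitting at the limit, the expectation for compound 4 is that it too stays there, estimated at 100000 nM with a range from 30000 nM to 300000 nM. That estimate means a number no higher from compound 3 to compound 4 (the limit leaves the size open), expected to be no change beyond the scatter.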

Compound 4, half-maximal inhibitory concentration: 99300 nM
The estimate for compound 4 lay 1.0-fold (0.00 log units) above the measured number, within the range that was stated.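

In this assay, among the compounds shown here, compound 4 gives 99300 nM, the only true number among the four compounds, so a 2,4-difluorophenyl on this aromatic carbon yields a reading that the assay can express as a number. Compound 3 gives > 100000 nM, which is a limit of the assay and not a number. The steps of a number no higher from compound 2 to compound 4 (the limit leaves the size open) and a number no higher from compound 1 to compound 4 (the limit leaves the size open) cannot be sized, so the gain from this change could be very small or larger: the limit of > 100000 nM in this assay, at which 3 of the 4 values shown sit.

The compounds shown do not separate the two fluorines: they enter together in the step of a number no higher from compound 3 to compound 4 (the limit leaves the size open) and it stays open whether a phenyl with a single fluorine would also give a number in this assay. As far as these compounds go, it is also open what this aromatic carbon would tolerate if the phenyl carried an amine or a carboxylic acid instead.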